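Trifluoromethyl for Chloro on the Aromatic Ring

A few compounds are considered here, and "the series" means these few. Any claim that something is new, unique, unknown or untested is made for them only; others in the source may bear on it.

Compound 1, `Sc1nnc(-c2ccccn2)o1`: 580 nM
Compound 2, `Sc1nnc(-c2cccc(Cl)c2)o1`: 210 nM
Compound 3, `Sc1nnc(-c2ccccc2Br)o1`: 980 nM

These three compounds share one core and were tested in an assay (Populus sieboldii x Populus grandidentata) for inhibition of Trans-cinnamate 4-monooxygenase (Populus kitakamiensis), with a stated time of 60 min; a lower number here means a stronger inhibitor, a higher number a weaker inhibitor. Compound 2 stands at the lowest number of the three; its gaps to compound 1 and to compound 3 both lie beyond the usual scatter, so among these measured compounds it is the strongest inhibitor. For the measured compounds named here, compound 1 and compound 3 carry different groups on the six-membered ring, so no single step between measured compounds isolates what one change on that ring does.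

Compound 4, `FC(F)(F)c1cccc(-c2nnc(S)o2)c1`, has not yet been measured. It differs from compound 2 by a single change: trifluoromethyl in place of chloro on an aromatic carbon. The group that leaves and the group that enters both lack donors, acceptors and charge, and the place on the ring is unchanged. Without a measured step of this kind, the expected change in this assay from compound 2 to compound 4 is small, in either direction or none beyond the scatter, which is what the estimated step of a 1.4-fold higher number from compound 2 to compound 4 (0.15 log units; within the scatter) expresses. Compound 4 is therefore expected to give about 300 nM, within a range from 120 nM to 800 nM.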

Compound 4, half-maximal inhibitory concentration: > 100000 nM
Compound 4: only a limit was reported (the forecaster's own chance of this, stated with the estimate: 5%); at least 330-fold (2.52 log units) between middle value and limit.
By their numbers in this assay, from the lowest: compound 2; then compounds 1 and 3 (each within the scatter of the next). At a limit, above all of these: compound 4.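

In this assay, trifluoromethyl in place of chloro on this aromatic carbon gives an at least 470-fold higher number from compound 2 to compound 4 (2.67 log units; beyond the scatter), so two groups that both lack donors, acceptors and charge can behave very differently at this one place. For the compounds shown here, the earlier compounds offered no single change on this ring; this step is the first to show that one swap here can carry the number all the way to the limit of the assay. For compound 4 the reported figure is a limit and not a number: the limit of > 100000 nM in this assay, at which 1 of the 4 values shown sits.

The compounds shown do not tell which feature of trifluoromethyl lies behind so large a step. As far as these compounds go, it also remains open how a methyl group, an amine or a carboxylic acid would fare at this same place on the ring.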